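Ethyl for bromo on the chalcone aryl ring

The source may hold more compounds than are shown below. What is called first, only, known or untested is meant among the compounds shown, and "the series" means these compounds.

Compound 1 `O=C(/C=C/c1ccc2c(c1)B(O)OC2)c1ccc(-c2ccccc2)cc1` gives 6400 nM. Compound 2 `O=C(/C=C/c1ccc2c(c1)B(O)OC2)c1ccc(F)cc1` gives 1600 nM. Compound 3 `O=C(/C=C/c1ccc2c(c1)B(O)OC2)c1ccc(Br)cc1` gives 9500 nM.

In a functional assay on MDA-MB-231 cells (Homo sapiens) for cytotoxicity, read by MTT assay, with a stated time of 48 h (a lower number here means a stronger inhibitor, a higher number a weaker inhibitor), compound 3 stands at the highest of the three numbers. Its nearest neighbour is compound 1, and the step of a 1.5-fold higher number from compound 1 to compound 3 (0.17 log units; within the scatter). Its furthest neighbour is compound 2, and the step of a 5.9-fold higher number from compound 2 to compound 3 (0.77 log units; beyond the scatter). The step of a 4.0-fold lower number from compound 1 to compound 2 (0.60 log units; beyond the scatter) shows the same pull toward the smaller number for fluoro.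

Compound 4 `CCc1ccc(C(=O)/C=C/c2ccc3c(c2)B(O)OC3)cc1` differs from compound 3 in one place: ethyl in place of bromo on an aromatic carbon. For the measured compounds named here, no measured step introduces ethyl, so the comparison rests on what the substituents already seen have done at that position. Phenyl and bromo sit close together, and only fluoro moves the number clearly downward. Ethyl is neither of these, and nothing measured here points to a shift beyond the scatter in either direction. The step expected from compound 3 to compound 4 is therefore a 1.6-fold lower number from compound 3 to compound 4 (0.20 log units; within the scatter), with a slight lean toward a lower number. Compound 4 is expected to give 6000 nM in this assay, within a range of 2500 nM to 14000 nM.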

Compound 4, half-maximal inhibitory concentration: 9800 nM
Beside the measured number, compound 4's estimate is 1.6-fold (0.21 log units) below it; the measured number falls inside the stated range.
By their numbers in this assay, from the lowest: compound 2; then compounds 1, 3 and 4 (each within the scatter of the next).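

Ethyl in place of bromo leaves the number where it was in this assay (a 1.0-fold higher number from compound 3 to compound 4 (0.01 log units; within the scatter)), and this is the first non-halogen, non-aryl group seen at this position. Ethyl also reads alike with phenyl (a 1.5-fold higher number from compound 1 to compound 4 (0.19 log units; within the scatter)), so three quite different groups now form one cluster, while the gap to fluoro stays beyond the scatter (a 6.1-fold higher number from compound 2 to compound 4 (0.79 log units; beyond the scatter)); fluoro, not bromo or phenyl, is the group that stands apart, and it is a single compound against three. Nothing available on these compounds bears on why fluoro alone separates from the others.

From the compounds shown here alone, whether chloro, methoxy, an amine or a carboxylic acid at this position would fall with fluoro or with the cluster of phenyl, bromo and ethyl remains open, and so does whether a longer chain would stay with ethyl. The compounds shown also leave open whether the separation of fluoro holds for the same groups placed elsewhere on this ring, or on a different core.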